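The compounds below may be only part of what the source reports. "The series", "measured", "known", "first", "only" and "open" are said of these compounds alone.

The series shares one core, carried here by compound 3 `CN[C@@H]1CCN(c2cc3c(cc2F)c(=O)c(C(=O)O)cn3Cc2ccc(-c3ccccc3)cc2)C1`. In an assay on isolated protein for inhibition of DNA topoisomerase 1 (Homo sapiens), with a stated time of 15 min (on this read-out higher numbers stand for weaker inhibition and lower numbers for stronger inhibition), compound 3 gives 34800 nM. Compound 1 `N[C@@H]1CCN(c2cc3c(cc2F)c(=O)c(C(=O)O)cn3Cc2ccc(-c3ccccc3)cc2)C1` carries a hydrogen where compound 3 carries a methyl on the amine nitrogen. In this assay compound 1 gives 63600 nM. The step of a 1.8-fold lower number from compound 1 to compound 3 (0.26 log units; within the scatter) is within the scatter, so the two values cannot be placed in any order. Compound 2 `COc1c(N2CC[C@@H](CO)C2)c(F)cc2c(=O)c(C(=O)O)cn(Cc3ccc(-c4ccccc4)cc3)c12` returns only a limit in this assay, > 200000 nM, and therefore no number.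

The step to compound 4 `CN[C@@H]1CCN(c2c(F)cc3c(=O)c(C(=O)O)cn(Cc4ccc(-c5ccccc5)cc4)c3c2OC)C1` is methoxy in place of hydrogen on an aromatic carbon. Among the measured compounds shown here, the only measured step in the set, hydrogen to methyl on the amine nitrogen, does not touch the aromatic ring and does not bear on this change. For the measured compounds named here, the one compound that does carry a methoxy on that aromatic carbon, compound 2, sits at the limit (the limit of > 200000 nM in this assay, at which 1 of the 3 values shown sits), though it differs from compound 3 at the pyrrolidine substituent as well, so no step is computed for it. On this basis the number for compound 4 is expected to come out higher rather than lower, and the expected step is a 2.0-fold higher number from compound 3 to compound 4 (0.30 log units; within the scatter). The estimate for compound 4 in this assay is 70000 nM, within a range from 25000 nM to 200000 nM.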

Compound 4, half-maximal inhibitory concentration: 57700 nM
For compound 4 the middle estimate is 1.2-fold (0.08 log units) above the measured one; measured number inside the range.
By their numbers in this assay, from the lowest: compounds 3, 4 and 1 (each within the scatter of the next). At a limit, above all of these: compound 2.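

With the 3-(methylamino)pyrrolidin-1-yl group held in place, methoxy in place of hydrogen on this aromatic carbon, ortho to that group and meta to the fluoro group, gives a 1.7-fold higher number from compound 3 to compound 4 (0.22 log units; within the scatter), so in this assay the two compounds cannot be placed in any order. The methoxy group alone therefore does not take a compound to the limit, since methylamino in place of hydroxymethyl on the saturated ring carbon, with the methoxy group present in both compounds, gives an at least 3.4-fold lower number from compound 2 to compound 4 (0.53 log units; beyond the scatter). Compound 2 stands at a limit and not at a number, so that step has only a minimum size: the limit of > 200000 nM in this assay, at which 1 of the 4 values shown sits.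

The compounds shown leave open whether an ethoxy or a chloro group on this aromatic carbon would separate from hydrogen and methoxy in this assay, and whether hydroxymethyl on the saturated ring would reach the limit without the methoxy group. They also leave open how a longer chain on the amine nitrogen, such as an ethyl group, would read.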